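This account rests on a few compounds, and the source may have more. Where it says the series, first, only, none or still open, it means among the compounds named here.

Compound 1 `N#CC1=C(N)N(c2ccc(S(N)(=O)=O)cc2)C2=C(CCCC2)C1c1ccccc1`: 20% in a functional assay on Ehrlich cells (Mus musculus) for cytotoxicity, read by trypan blue exclusion, with a stated time of 2 h, tested at 50 ug/mL; a lower number here means a weaker effect, a higher number a stronger effect of the compound at the concentration tested
Compound 2 `COc1ccccc1C1C(C#N)=C(N)N(c2ccc(S(N)(=O)=O)cc2)C2=C1CCCC2`: 50% in this assay
Compound 3 `N#CC1=C(N)N(c2ccc(S(N)(=O)=O)cc2)C2=C(CCCC2)C1c1ccc(Cl)c(Cl)c1`: not yet measured in this assay

Going by the values given here, compound 2 stands highest of the two measured numbers; the nearest, compound 1, lies lower by a step that is beyond the scatter, as the single measured step of a number 30 percentage points higher from compound 1 to compound 2 (beyond the scatter) shows. The change to compound 3 is 3,4-dichlorophenyl in place of 2-methoxyphenyl on a saturated ring carbon. Among the compounds with values here, the only measured step that touches the same position is a number 30 percentage points higher from compound 1 to compound 2 (beyond the scatter), where a methoxy replaced hydrogen on the aromatic ring and gave a modest gain. That step says substitution on this aromatic ring can raise the read-out, but nothing measured tells how the 3,4-dichlorophenyl compares with the 2-methoxyphenyl, since the methoxy leaves while two chlorines enter. The expectation for compound 3 in this assay is therefore a step of about a number 10 percentage points lower from compound 2 to compound 3 (within the scatter), a change not clearly beyond the scatter and of uncertain direction. Compound 3 is estimated at 40%, with a range from 15% to 65%.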

Compound 3, a percentage reported as activity, at one concentration (the size of the read-out at that concentration, not a potency): 50%
For compound 3 the middle estimate is 10 percentage points below the measured one, within the range that was stated.
By their numbers in this assay, from the lowest: compound 1; then compounds 2 and 3 (each within the scatter of the next).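

In this assay, 3,4-dichlorophenyl takes the place of 2-methoxyphenyl on the saturated ring carbon with no change at the digits printed from compound 2 to compound 3 (within the scatter), so at this position the methoxy oxygen is not needed for a read-out at the level of compound 2. Set against the unsubstituted phenyl, the same group gives a number 30 percentage points higher from compound 1 to compound 3 (beyond the scatter), which stands alongside a number 30 percentage points higher from compound 1 to compound 2 (beyond the scatter): two differently substituted phenyl rings both lie apart from compound 1, and neither substituted compound shown goes against this. The evidence at hand offers no explanation for why these two groups read alike or why both differ from phenyl.

Open, as far as these compounds go, is whether the gain over phenyl extends to substituents of other kinds, such as a carboxylic acid or an amine on the phenyl ring, or to a pyridine ring in its place. Also open, from the compounds shown here alone, is how compound 2 and compound 3 would compare at other concentrations, since each read-out here gives the size of the effect at a single concentration and is not a potency.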